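The source may hold more compounds than are shown below. What is called first, only, known or untested is meant among the compounds shown, and "the series" means these compounds.

Among the measured compounds shown here, compound 2 `COC(=O)c1ccnc(O[C@@H]2CC[C@@H](C)N(C(=O)c3ccccc3-n3nccn3)C2)c1` is one of three compounds measured in an assay on CHO-K1 cells for displacement of a labelled ligand from Orexin/Hypocretin receptor type 1 (Homo sapiens), read by radioligand binding; a lower number here means a stronger inhibitor, a higher number a weaker inhibitor. Compound 2 gives 310 nM, the second highest of the three numbers. Its nearest neighbour is compound 3 `C[C@@H]1CC[C@@H](Oc2cc(-c3ccccc3)ccn2)CN1C(=O)c1ccccc1-n1nccn1`, which gives 360 nM in this assay; the distance between them, a 1.2-fold higher number from compound 2 to compound 3 (0.06 log units; within the scatter), lies within the scatter. The furthest is compound 1 `C#Cc1ccnc(O[C@@H]2CC[C@@H](C)N(C(=O)c3ccccc3-n3nccn3)C2)c1`, which gives 49 nM in this assay; the step of a 6.3-fold higher number from compound 1 to compound 2 (0.80 log units; beyond the scatter) is modest but beyond the scatter, as is a 7.3-fold higher number from compound 1 to compound 3 (0.87 log units; beyond the scatter).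

Compound 4 `Cc1cccnc1O[C@@H]1CC[C@@H](C)N(C(=O)c2ccccc2-n2nccn2)C1` is not yet measured. It differs from compound 2 in one place (3-methylpyridin-2-yl in place of 4-(methoxycarbonyl)pyridin-2-yl on an oxygen on a saturated carbon). For the measured compounds named here, the measured steps all exchange the group carried on the 4-(methoxycarbonyl)pyridin-2-yl ring for another group in the same place; none removes that group and none places a methyl on the 3-methylpyridin-2-yl ring, so no measured step bears directly on this change. The two larger steps, a 6.3-fold higher number from compound 1 to compound 2 (0.80 log units; beyond the scatter) and a 7.3-fold higher number from compound 1 to compound 3 (0.87 log units; beyond the scatter), show that a change on this ring can move the number beyond the scatter in either direction. Compound 4 is therefore expected to give roughly 250 nM in this assay, within a wide range from 50 nM to 1200 nM, which means an expected step of a 1.2-fold lower number from compound 2 to compound 4 (0.09 log units; within the scatter).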

Compound 4, inhibition constant: 4760 nM
Estimate against measurement, compound 4: 19-fold (1.28 log units) below, outside the stated range (above it).
By their numbers in this assay, from the lowest: compound 1; then compounds 2 and 3 (each within the scatter of the next); then compound 4.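

In this assay, 3-methylpyridin-2-yl in place of 4-(methoxycarbonyl)pyridin-2-yl gives a 15-fold higher number from compound 2 to compound 4 (1.19 log units; beyond the scatter), and the same group in place of 4-ethynylpyridin-2-yl gives a 97-fold higher number from compound 1 to compound 4 (1.99 log units; beyond the scatter). Both steps are large, whereas exchanging ethynyl, methoxycarbonyl and phenyl on the ring gave steps that were only modest or within the scatter, so changing the whole group on this oxygen can move the number further than those exchanges did. Nothing available here accounts for the size of these steps.

The compounds shown leave open whether the higher number of compound 4 goes with the methyl group that enters or with the loss of the group on the 4-substituted ring, a question that plain pyridin-2-yl and 4-methylpyridin-2-yl would separate. They also leave open how an amine or a carboxylic acid in place of the ethynyl of compound 1 would read.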